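Cytotoxicity notes on a bicyclic lactam series: compounds 3 and 4

The compounds below may be only part of what the source reports. "The series", "measured", "known", "first", "only" and "open" are said of these compounds alone.

Measured so far in a functional assay on SW-620 cells (Homo sapiens) for cytotoxicity; on this read-out lower numbers stand for stronger inhibition of growth and higher numbers for weaker inhibition of growth:
compound 1 `COc1ccc(C2=C(c3ccc(SC)cc3)CC3CCCN3C2=O)cc1OC(=O)CNC(=O)OC(C)(C)C` — 20000 nM
compound 2 `COc1ccc(C2=C(c3ccc(SC)cc3)CC3CCCN3C2=O)cc1C` — 500 nM
compound 3 `CSc1ccc(C2=C(c3ccc(O)c(O)c3)C(=O)N3CCCC3C2)cc1` — 50000 nM

Compound 3 stands at the highest of the three numbers. Its nearest neighbour is compound 1, which gives 20000 nM, and its furthest is compound 2, which gives 500 nM; both gaps lie beyond the scatter.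

Compound 4 `CSc1ccc(C2=C(c3ccc(SC)cc3)C(=O)N3CCCC3C2)cc1` differs from compound 3 in one place: 4-(methylsulfanyl)phenyl in place of 3,4-dihydroxyphenyl on a double-bonded ring carbon. Neither measured step covers this exact exchange. The step of a 100-fold higher number from compound 2 to compound 3 (2.00 log units; beyond the scatter) is the closest: there the 3,4-dihydroxyphenyl group entered and the number rose sharply. The step of a 40-fold lower number from compound 1 to compound 2 (1.60 log units; beyond the scatter) shows the other large movement in the set, where a group of 12 heavy atoms left and the number fell. In compound 4 the 3,4-dihydroxyphenyl group leaves again, and a group with 0 hydrogen-bond donors enters, so a large step downward in this assay is expected, of roughly the size of a 50-fold lower number from compound 3 to compound 4 (1.70 log units; beyond the scatter), bringing compound 4 back toward the region of compound 2. The estimate for compound 4 is 1000 nM, with a range of 200 nM to 5000 nM.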

Compound 4, concentration for 50% growth inhibition: 7000 nM
Compound 4: middle estimate off by 7.0-fold (0.85 log units), on the low side; measured number outside the range, above it.
By their numbers in this assay, from the lowest: compound 2; then compound 4; then compound 1; then compound 3.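

At the double-bonded ring carbon of the shared core, the exchange of 3,4-dihydroxyphenyl for 4-(methylsulfanyl)phenyl in this assay gives a 7.1-fold lower number from compound 3 to compound 4 (0.85 log units; beyond the scatter) as a modest step, so a group with 0 hydrogen-bond donors in this place does not by itself restore the level of compound 2. A large gap remains in a 14-fold higher number from compound 2 to compound 4 (1.15 log units; beyond the scatter) and this separates the three groups compared at this carbon into three levels, with 4-methoxy-3-methylphenyl giving the lowest number, 4-(methylsulfanyl)phenyl the middle one and 3,4-dihydroxyphenyl the highest. No measurement here gives a reason for this order.

As far as these compounds go, it remains open which part of 4-methoxy-3-methylphenyl, the methoxy or the methyl, goes with the lowest number, and whether either alone on the phenyl ring would hold that level. The compounds shown also leave open how a phenyl ring carrying an amine or a carboxylic acid would behave at this carbon, and whether the order of the three groups would hold with a different substituent on the other aryl ring of the core.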